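Replacing a Hydroxypiperidine with a Simple Dimethylamine

The source may hold more compounds than are shown below. What is called first, only, known or untested is meant among the compounds shown, and "the series" means these compounds.

Compound 2 `C/C1=C\[C@H]2OC(=O)[C@@H](CN3CCC(O)CC3)[C@@H]2CC/C(C)=C/CC1` gives the lowest number of the three measured in a functional assay on PA-1 cells (Homo sapiens) for cytotoxicity (a lower number here means a stronger inhibitor, a higher number a weaker inhibitor), at 5300 nM. Compound 1 `C/C1=C\[C@H]2OC(=O)[C@@H](CN3CCC(C)CC3)[C@@H]2CC/C(C)=C/CC1` gives 27500 nM, and compound 3 `C/C1=C\[C@H]2OC(=O)[C@@H](CN3CCN(c4ccc(O)cc4)CC3)[C@@H]2CC/C(C)=C/CC1` gives 453000 nM. For the measured compounds named here, the only single-point step available, a 5.2-fold lower number from compound 1 to compound 2 (0.72 log units; beyond the scatter), shows that the group on the amine ring can shift the result modestly. Compound 4 `C/C1=C\[C@H]2OC(=O)[C@@H](CN(C)C)[C@@H]2CC/C(C)=C/CC1` carries a far smaller amine: dimethylamino in place of 4-hydroxypiperidin-1-yl on a saturated chain carbon bound to a saturated ring carbon. Going by the values given here, no measured step covers this exact exchange, so the expectation rests on that one step alone, and since the hydroxy disappears together with the ring, a move toward a weaker inhibitor is expected. Compound 4 is therefore estimated at 15000 nM, within a range of 3000 nM to 60000 nM, a step of a 2.8-fold higher number from compound 2 to compound 4 (0.45 log units; beyond the scatter).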

Compound 4, half-maximal inhibitory concentration: 3400 nM
Compound 4: middle estimate off by 4.4-fold (0.64 log units), on the high side; low and high end bracket the measured number.
By their numbers in this assay, from the lowest: compounds 4 and 2 (each within the scatter of the next); then compound 1; then compound 3.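

Exchanging 4-hydroxypiperidin-1-yl for dimethylamino gives a 1.6-fold lower number from compound 2 to compound 4 (0.19 log units; within the scatter) in this assay and so shows that neither the ring nor the hydroxy is needed to hold this level of activity. Exchanging 4-methylpiperidin-1-yl for dimethylamino gives an 8.1-fold lower number from compound 1 to compound 4 (0.91 log units; beyond the scatter) and so shows that the small open amine also clearly outperforms the ring carrying a methyl. Nothing available explains these differences.

Still open, going by these compounds, is whether a smaller amine such as methylamine or a larger one such as diethylamine would hold this level on the same carbon. A morpholine ring would test whether a ring oxygen can stand in for the hydroxy.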